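The compounds below may be only part of what the source reports. "The series", "measured", "known", "first", "only" and "open" are said of these compounds alone.

In an ADME assay on cells (Hepatocyte, Mus musculus) for metabolic stability (a lower number here means that the compound disappears faster, a higher number that the compound lasts longer), compound 1 (`Cn1ncc2cc(-c3cnc4[nH]ccc4c3N3CCC4(CCNC4=O)CC3)ccc21`) gives 0.15 h and lies within the scatter of both compound 2 (`Cn1ncc2cc(-c3cnc4[nH]ncc4c3N3CCC4(CCNC4=O)CC3)ccc21`) at 0.183 h and compound 3 (`Cn1ncc2cc(-c3cnc4[nH]cnc4c3N3CCC4(CCNC4=O)CC3)ccc21`) at 0.0833 h on the same read-out. Compound 4 (`Cn1ncc2cc(-c3cnc4[nH]cc(Cl)c4c3N3CCC4(CCNC4=O)CC3)ccc21`) differs from compound 1 in one place (chloro in place of hydrogen on an aromatic carbon): chloro in place of hydrogen on an aromatic carbon of a five-membered aromatic ring with 1 nitrogen, two ring bonds from the ring nitrogen. Within the data shown here, no measured pair in this set isolates a single change, so the data give no direct guide, and no step beyond the scatter is expected in this assay in either direction. The expected change is no change at the digits printed from compound 1 to compound 4 (within the scatter) (an estimate only). For compound 4 the estimated half-life is 0.15 h (expected range 0.07 h to 0.32 h).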

Compound 4, half-life: 0.183 h
Compound 4: middle estimate off by 1.2-fold (0.09 log units), on the low side, within the range that was stated.
By their numbers in this assay, from the lowest: compounds 3, 1, 2 and 4 (each within the scatter of the next, the first and the last beyond it).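

In this assay, among these compounds, the swap of hydrogen for chloro on the aromatic carbon two ring bonds from the ring nitrogen gives a 1.2-fold higher number from compound 1 to compound 4 (0.09 log units; within the scatter) and is the first single-place step. This carbon therefore carries a chloro with no step beyond the scatter. Nothing available bears on the reason for this result.

On these data alone, whether a nitrile, a methoxy group or an amine on this carbon would give a step beyond the scatter stays open. As far as these compounds go, whether chloro on this carbon reads the same with another group on the rest of the shared core also stays open.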